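A few compounds are considered here, and "the series" means these few. Any claim that something is new, unique, unknown or untested is made for them only; others in the source may bear on it.

Among the three compounds tested so far, compound 2 `CC(C)CCn1ccc(-c2ccc(Oc3ccccc3)cc2)c(C#N)c1=O` stands lowest in a functional assay on CHO cells for positive allosteric modulation of metabotropic glutamate receptor 2 (Homo sapiens), read by scintillation counting and GTPgammaS binding, with a stated time of 30 min (a lower number here means that less compound is needed, a higher number that more compound is needed for the effect), with 42 nM. Compound 3 `CC(C)CCn1ccc(-c2ccc(NC3CCOCC3)c(Cl)c2)c(C#N)c1=O` lies next with 174 nM in this assay, a gap beyond the usual scatter, and compound 1 `COc1ccc(-c2ccn(CCC(C)C)c(=O)c2C#N)cc1F` is furthest away at 1170 nM. The next compound, compound 4 `Cc1cc(Oc2ccc(-c3ccn(CCC(C)C)c(=O)c3C#N)cc2)ccn1`, is built from compound 2 by a single change: 2-methylpyridin-4-yl in place of phenyl on an oxygen on an aromatic ring. Among the measured compounds shown here, no measured pair in this set shares that change, so its effect has to be judged without a direct precedent. The step from compound 2 to compound 4 is expected to be small, reading a 1.7-fold higher number from compound 2 to compound 4 (0.22 log units; within the scatter), with no clear direction beyond the scatter. Compound 4 is therefore estimated at 70 nM in this assay, within a range of 20 nM to 250 nM.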

Compound 4, half-maximal effective concentration: 447 nM
Estimate against measurement, compound 4: 6.4-fold (0.81 log units) below, and the stated range ends below it.
By their numbers in this assay, from the lowest: compound 2; then compound 3; then compound 4; then compound 1.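

In this assay, the group on an oxygen on an aromatic ring proves sensitive to change: 2-methylpyridin-4-yl in place of phenyl gives an 11-fold higher number from compound 2 to compound 4 (1.03 log units; beyond the scatter), a large step beyond the scatter. Among the compounds shown here, the earlier compounds offered no pair differing in one place, so this is the first direct reading of any single change in the set. Nothing at hand accounts for the size of this step. The compounds shown leave open whether the step follows the ring nitrogen or the methyl: pyridin-4-yl without the methyl, or a methylphenyl on the same oxygen, would separate the two.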